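A methoxy swap on a hydroxamate stilbene

The source may report more compounds than this note shows. Statements on the series, on what has been measured and on what is new or still open speak of the compounds shown alone.

Among the compounds with values here, compound 1 `O=C(NO)c1ccc(/C=C/c2ccnc(-c3cc(F)ccc3O)c2)cc1` is the only compound with a plain number in a functional assay on HCT-116 cells (Homo sapiens) for antiproliferative activity, read by CellTiter-Glo, with a stated time of 72 h (a lower number here means a stronger inhibitor, a higher number a weaker inhibitor), where compound 1 gives 2040 nM. Compound 2 `O=C(NO)c1ccc(/C=C/c2ccnc(-c3ccc(C(F)(F)F)cc3)c2)cc1` gives > 10000 nM, which is a limit of this assay rather than a number, namely (the limit of > 10000 nM in this assay, at which 1 of the 2 values shown sits). Compound 3 `COc1ccc(-c2cc(/C=C/c3ccc(C(=O)NO)cc3)ccn2)cc1` differs from compound 1 by 4-methoxyphenyl in place of 5-fluoro-2-hydroxyphenyl on an aromatic carbon. Within the data shown here, no measured step covers this pair. The hydrogen-bond donor of compound 1 departs, and compound 2, without such a donor, sits at the limit; the expected 2.7-fold higher number from compound 1 to compound 3 (0.43 log units; beyond the scatter) is therefore a weakening beyond the scatter. Compound 3 is estimated at 5500 nM, between 1800 nM and 16000 nM.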

Compound 3, half-maximal inhibitory concentration: 3560 nM
Estimate against measurement, compound 3: 1.5-fold (0.19 log units) above, within the range that was stated.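

In this assay, the change on the aromatic carbon next to the ring nitrogen gives a 1.7-fold higher number from compound 1 to compound 3 (0.24 log units; within the scatter), so the hydrogen-bond donor of the 5-fluoro-2-hydroxyphenyl group is not needed to hold the number at this position. The ring substituent still counts, since the other change gives an at least 2.8-fold lower number from compound 2 to compound 3 (0.44 log units; beyond the scatter). Compound 2 stands at a limit of the assay: the limit of > 10000 nM in this assay, at which 1 of the 3 values shown sits.

The compounds shown leave open how an amine or a carboxylic acid on this phenyl ring would read. They also leave open whether the fluorine and the hydroxy group of compound 1 each count separately.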